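Changing the aryl group on a shared core

A few compounds are considered here, and "the series" means these few. Any claim that something is new, unique, unknown or untested is made for them only; others in the source may bear on it.

Of the compounds shown here, three of one shared core have been tested so far in a functional assay on HepG2 cells (Homo sapiens) for antiproliferative activity, read by MTT assay, with a stated time of 48 h; on this read-out lower numbers stand for stronger inhibition and higher numbers for weaker inhibition. Compound 1 `Cc1ccccc1-n1nncc1CN1C(=O)C2(C(C#N)=C(N)Oc3c(N)cc4nc5ccccc5nc4c32)c2ccccc21` carries a 2-methylphenyl on an aromatic nitrogen, and in this assay compound 1 reaches only the limit of > 50000 nM, which is a boundary of the test and not a number. Compound 2 `N#CC1=C(N)Oc2c(N)cc3nc4ccccc4nc3c2C12C(=O)N(Cc1cnnn1-c1cccc(Br)c1)c1ccccc12` carries a 3-bromophenyl at the same place, and compound 2 likewise stops at the limit of > 50000 nM. Compound 3 `COc1ccc(-n2nncc2CN2C(=O)C3(C(C#N)=C(N)Oc4c(N)cc5nc6ccccc6nc5c43)c3ccccc32)cc1` carries a 4-methoxyphenyl, and compound 3 also sits at the limit of > 50000 nM. Because of the limit of > 50000 nM in this assay, at which 3 of the 3 values shown sit, none of the steps between them can be read: a step that the two limits leave unreadable from compound 1 to compound 3 and a step that the two limits leave unreadable from compound 2 to compound 3 stay unreadable, as does a step that the two limits leave unreadable from compound 1 to compound 2.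

Compound 4 `Cc1ccc(-n2nncc2CN2C(=O)C3(C(C#N)=C(N)Oc4c(N)cc5nc6ccccc6nc5c43)c3ccccc32)cc1C` differs from compound 3 in one place: 3,4-dimethylphenyl in place of 4-methoxyphenyl on an aromatic nitrogen. Three different aryl groups at this position have all left the series without measurable inhibition, so a fourth aryl group is expected to behave the same way, with no step beyond the scatter; the step that the limit leaves unreadable from compound 3 to compound 4 is expected to be nothing readable. Compound 4 is therefore estimated at 70000 nM, within 20000 nM to 250000 nM, most likely again reported only as a limit.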

Compound 4, half-maximal inhibitory concentration: > 50000 nM
Compound 4 ended at the assay's limit; the forecaster's own chance of this, stated with the estimate: 85%; the middle value is on the limit's open side.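

In this assay compound 4 stops at > 50000 nM, which is a limit of the test and not a number. No step between compound 4 and compound 1, compound 2 or compound 3 can be read, because all four compounds end at the same boundary: the limit of > 50000 nM in this assay, at which 4 of the 4 values shown sit.

The compounds shown leave open whether any aryl group at this place on the shared core gives measurable inhibition in this assay.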